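This account rests on a few compounds, and the source may have more. Where it says the series, first, only, none or still open, it means among the compounds named here.

Measured to date:
compound 1 `O=c1oc2ccccc2c(N2CCN(c3cccc(Cl)c3Cl)CC2)c1CO` — 45900 nM
compound 2 `COc1cccc(N2CCN(c3c(CO)c(=O)oc4ccccc34)CC2)c1` — 38100 nM
compound 3 `O=c1oc2ccccc2c(N2CCN(c3ccc(Cl)c(Cl)c3)CC2)c1CO` — 42700 nM

All three values come from a functional assay on WM1361 cells (Homo sapiens) for inhibition, read by MTT assay, with a stated time of 24 h; on this read-out lower numbers stand for stronger inhibition and higher numbers for weaker inhibition. Compound 1 gives the highest of the three numbers, but its gap to either neighbour is within the scatter: the step of a 1.2-fold lower number from compound 1 to compound 2 (0.08 log units; within the scatter) and the step of a 1.1-fold lower number from compound 1 to compound 3 (0.03 log units; within the scatter) are both small, as is the step of a 1.1-fold higher number from compound 2 to compound 3 (0.05 log units; within the scatter). The three compounds therefore cannot be ranked against each other on this read-out.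

Compound 4 `CCN1CCN(c2c(CO)c(=O)oc3ccccc23)CC1` has not yet been measured in this assay. Against compound 1 the change is ethyl in place of 2,3-dichlorophenyl on an amine nitrogen in a ring.

The measured steps all exchange one six-membered aromatic ring of carbon only for another on the same amine nitrogen in a ring; none exchanges such a ring for a chain. They show that the pattern on that ring has not moved the number beyond the scatter, but they say nothing about removing the ring itself. As far as these compounds go, the step to ethyl is untested, and no direction can be read from it. Going by the values given here, with no bearing step, the expectation for compound 4 is set near compound 1 with a wide range, and the expected step of a 1.2-fold higher number from compound 1 to compound 4 (0.08 log units; within the scatter) is taken as lying within the scatter. Compound 4 is expected to give 55000 nM in this assay, estimated between 20000 nM and 150000 nM.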

Compound 4, half-maximal inhibitory concentration: > 100000 nM
Compound 4: only a limit was reported (the forecaster's own chance of this, stated with the estimate: 25%); middle value at least 1.8-fold (0.25 log units) from the limit.
By their numbers in this assay, from the lowest: compounds 2, 3 and 1 (each within the scatter of the next). At a limit, above all of these: compound 4.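

In this assay compound 4 gives only a limit and no number: the limit of > 100000 nM in this assay, at which 1 of the 4 values shown sits. Even so, the steps can be read as lower bounds, and they are the first at this position to lie beyond the scatter: an at least 2.1-fold higher number from compound 1 to compound 4 (0.33 log units; beyond the scatter), an at least 2.3-fold higher number from compound 3 to compound 4 (0.36 log units; beyond the scatter) and an at least 2.6-fold higher number from compound 2 to compound 4 (0.41 log units; beyond the scatter), each with ethyl in place of the group on the amine nitrogen in a ring. Exchanges among 2,3-dichlorophenyl, 3,4-dichlorophenyl and 3-methoxyphenyl stayed within the scatter, so in these four compounds replacing the six-membered aromatic ring of carbon only with ethyl counts for more on this read-out than changing the pattern on that ring.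

Ethyl differs from these groups both in having no ring and in its smaller heavy-atom count, so the compounds shown leave open whether a saturated ring such as cyclohexyl, or a longer chain such as hexyl, on that nitrogen would stay near compound 1 or go the way of compound 4. As far as these compounds go, the full size of the loss also stays open, since the limit for compound 4 gives only the least size of each step.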